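The source may report more compounds than this note shows. Statements on the series, on what has been measured and on what is new or still open speak of the compounds shown alone.

Three compounds have so far been examined in a functional assay on NCI-H460 cells (Homo sapiens) for inhibition, read by MTT assay, with a stated time of 24 h, tested at 10 ug/mL; on this read-out lower numbers stand for less inhibition of growth and higher numbers for more inhibition of growth at the one concentration tested. In this test, compound 1 `O=C(CCCCC1CCSS1)NO` is recorded as "not active" (no number reported), so it offers no number for comparison. Compound 2 `O=C(CCCCC(S)CCS)Nc1ccc([N+](=O)[O-])c(C(F)(F)F)c1` gives 0.97%, while compound 3 `CC(=O)SCCC(CCCCC(=O)Nc1ccccc1)SC(C)=O` gives 14.2%. Compound 3 therefore holds the higher of the two numerical results, and its gap to compound 2 lies beyond the usual scatter of the measurement. Even so, this remains a low level of growth inhibition at the single concentration tested.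

The next compound to be tested is compound 4 `CC(=O)SCCC(CCCCC(=O)Nc1ccc(Cl)cc1)SC(C)=O`, which departs from compound 3 at a single place: chloro in place of hydrogen on an aromatic carbon. In words, chloro takes the place of hydrogen on an aromatic carbon, turning phenyl into 4-chlorophenyl. For the measured compounds named here, no two measured compounds differ in one place alone, so the data hold no direct precedent for the size of this change. Only a small upward movement is therefore expected, and none beyond the scatter. The estimated change is a number 3.8 percentage points higher from compound 3 to compound 4 (within the scatter). For compound 4, the expected result in this assay is 18%, with an estimated range from 5% to 32%.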

Compound 4, percent growth inhibition at one concentration: 14.9%
Estimate against measurement, compound 4: 3.1 percentage points above; the measured number falls inside the stated range.
By their numbers in this assay, from the lowest: compound 2; then compounds 3 and 4 (each within the scatter of the next).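

In this assay, for the compounds shown here, a number 0.7 percentage points higher from compound 3 to compound 4 (within the scatter), and this is the first comparison here between two compounds that differ in one place only. It shows that, at this single concentration, placing chloro on this aromatic carbon, para to a large group, leaves compound 3 and compound 4 within the scatter of each other, so turning phenyl into 4-chlorophenyl gives no measurable separation in this read-out. No accompanying measurement bears on this result, so it stands without an explanation.

The compounds shown leave open whether any other group at this position, such as a methoxy group, an amine or a carboxylic acid, would move the number beyond the scatter, and whether chloro would behave the same way at another place on the ring. They also leave open what the acetyl groups on the two sulfur atoms contribute, since compound 2 differs from compound 3 and compound 4 in more than one place and so cannot settle that question.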